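The source may report more compounds than this note shows. Statements on the series, on what has been measured and on what is new or still open speak of the compounds shown alone.

Measured compounds:
- compound 1, `Cc1cccc(NC(=O)CN2CCC(c3ccc(Cl)cc3)CC2)c1`: "not active" (no number reported)
- compound 2, `CCc1cccc(NC(=O)CN2CCN(c3ccccn3)CC2)c1`: 26.2%
- compound 3, `Cc1cccc(NC(=O)CCN2CCN(c3ncccn3)CC2)c1`: "not active" (no number reported)

In an assay on cells for agonist activity at D(4) dopamine receptor (Homo sapiens), read by luminescence and beta-arrestin recruitment, with a stated time of 90 min (on this read-out lower numbers stand for smaller maximal responses and higher numbers for larger maximal responses), compound 1 gives "not active" (no number reported), with no number attached to the result. Compound 3 likewise gives "not active" (no number reported) in this assay. Only compound 2 returns a number: in this assay compound 2 gives 26.2%, a low maximal response. Compound 1 therefore stands among the two entries that carry no figure, and it is not ranked against compound 2 or compound 3 by a step, since none between these compounds is recorded.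

Compound 4, `Cc1ccc(C2CCN(CC(=O)Nc3cccc(C)c3)CC2)nc1`, is the untested member of the set. It differs from compound 1 by 5-methylpyridin-2-yl in place of 4-chlorophenyl on a saturated ring carbon. For the measured compounds named here, no step from compound 1 to another measured compound is available, so the size of the change in this assay can only be guessed. Compound 1 has no number to move from; any response above the scatter would count as a gain over compound 1, and a result with no number again would be no change. Given that compound 2 gives 26.2% in this assay and the two inactive entries, a small response at most is expected. For compound 4 the expected value in this assay is 18%, within a range of 0% to 40%.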

Compound 4, largest response reached (Emax), in percent of the reference or control that the assay uses: "not active" (no number reported)
Nothing numeric was reported for compound 4; the estimate stays without a comparison.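

In this assay, for the compounds shown here, compound 4 gives "not active" (no number reported) and compound 1 gives "not active" (no number reported) as well, so no step from compound 1 to compound 4 can be read. No evidence at hand bears on this result. The compounds shown leave open whether 5-methylpyridin-2-yl in place of 4-chlorophenyl alters the maximal response at all.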